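The source may report more compounds than this note shows. Statements on the series, on what has been measured and on what is new or still open speak of the compounds shown alone.

Of the compounds shown here, three that share one core have been tested in an assay on SH-EP1 cells for agonist activity at Neuronal acetylcholine receptor; alpha4/beta2 (Homo sapiens), read by FLIPR and calcium flux; a lower number here means that less compound is needed, a higher number that more compound is needed for the effect. Compound 1 `CC(=O)N1CC2CC(C1)N2` gives 5100 nM, compound 2 `CCC(=O)N1CC2CC(C1)N2` gives 490 nM, and compound 3 `O=C([C@@H]1C[C@@H]1F)N1CC2CC(C1)N2` gives 120 nM. Compound 3 stands lowest of the three: its nearest neighbour is compound 2, seen in a 4.1-fold lower number from compound 2 to compound 3 (0.61 log units; beyond the scatter), and the furthest is compound 1, seen in a 43-fold lower number from compound 1 to compound 3 (1.63 log units; beyond the scatter). Compound 4 `C[C@H]1C[C@H]1C(=O)N1CC2CC(C1)N2` differs from compound 3 by methyl in place of fluoro on a saturated ring carbon. Among the compounds with values here, no measured step swaps fluoro for methyl, so the closest guides are a 10-fold lower number from compound 1 to compound 2 (1.02 log units; beyond the scatter), where a single added carbon on the chain bound to the carbonyl carbon lowered the number a great deal, and a 4.1-fold lower number from compound 2 to compound 3 (0.61 log units; beyond the scatter), where the ring carrying fluorine beat the ethyl chain only modestly. Because a 4.1-fold lower number from compound 2 to compound 3 (0.61 log units; beyond the scatter) is modest, compound 4 is expected to land near compound 3, and the step of a 1.3-fold higher number from compound 3 to compound 4 (0.10 log units; within the scatter) is expected to stay within the usual scatter. The estimate for compound 4 in this assay is therefore 150 nM, expected to fall between 50 nM and 500 nM.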

Compound 4, half-maximal effective concentration: 2200 nM
Estimate against measurement, compound 4: 15-fold (1.17 log units) below, outside the stated range (above it).
By their numbers in this assay, from the lowest: compound 3; then compound 2; then compound 4; then compound 1.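

Fluoro and methyl each count as one heavy atom on the saturated ring carbon, yet in this assay exchanging them gives an 18-fold higher number from compound 3 to compound 4 (1.26 log units; beyond the scatter) and so this position tells the two groups sharply apart. The three-membered ring alone does not carry the gain seen with compound 3: a 4.5-fold higher number from compound 2 to compound 4 (0.65 log units; beyond the scatter) shows that 2-methylcyclopropyl needs more compound than ethyl on the carbonyl carbon, while a 2.3-fold lower number from compound 1 to compound 4 (0.37 log units; beyond the scatter) shows that it still needs less than methyl there. No measurement at hand explains why these two groups differ so much.

The compounds shown leave open whether the low number belongs to fluoro in particular or would also appear with chloro, hydroxyl or an amine on this ring carbon. They also leave open how plain cyclopropyl, with no group there, or a longer chain such as propyl on the carbonyl carbon would compare.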